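The compounds below may be only part of what the source reports. "The series", "measured", "known", "first", "only" and "open" are said of these compounds alone.

Measured compounds in an ADME assay for permeability, using PAMPA, with a stated time of 4 h, at pH 7.4; on this read-out lower numbers stand for lower permeability and higher numbers for higher permeability:
- compound 1, `c1ccc2c(c1)CN[C@H](CN(CCCN1CCNCC1)[C@H]1CCCc3cccnc31)C2`: 16 nm/s
- compound 2, `CC(C)N1CCN(CCCN(C[C@H]2Cc3ccccc3CN2)[C@H]2CCCc3cccnc32)CC1`: 344 nm/s

Of the two numbers in this assay, compound 1 stands lowest. Its nearest neighbour is compound 2, whose value is higher by a margin that lies beyond the scatter of repeated measurements, so the two compounds are genuinely set apart on this read-out. The two structures differ in more than one place, so that gap is only noted here and not traced to a single change.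

The next compound, compound 3, `c1cnc2c(c1)CCC[C@@H]2N(CCCN1CCNCC1)Cc1nc2ccccc2[nH]1`, is not yet measured. It differs from compound 1 in a single way: 1H-benzimidazol-2-yl in place of 1,2,3,4-tetrahydroisoquinolin-3-yl on a saturated chain carbon bound to an amine nitrogen. The rest of the shared core, including the piperazine and the three-carbon chain, stays the same.

Going by the values given here, no measured pair shows exactly this exchange, so the size of the step has to be estimated. Among the compounds with values here, a moderate rise in this assay is expected, on the order of the usual scatter or slightly beyond it, since the only comparison in hand, compound 2, points upward from compound 1. Compound 3 is therefore expected to give 35 nm/s, with a plausible range from 10 nm/s to 120 nm/s. The step from compound 1 to compound 3 is expected to be a 2.2-fold higher number from compound 1 to compound 3 (0.34 log units; beyond the scatter).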

Compound 3, apparent permeability: 146 nm/s
Compound 3: middle estimate off by 4.2-fold (0.62 log units), on the low side; measured number outside the range, above it.
By their numbers in this assay, from the lowest: compound 1; then compound 3; then compound 2.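

Going by these compounds alone, on a saturated chain carbon bound to an amine nitrogen, putting 1H-benzimidazol-2-yl in place of 1,2,3,4-tetrahydroisoquinolin-3-yl gives in this assay a 9.1-fold higher number from compound 1 to compound 3 (0.96 log units; beyond the scatter), the first change in this set that can be read at a single place, with the piperazine and the three-carbon chain left as they were. The two groups have the same count of hydrogen-bond donors and the same count of acceptors, so those counts do not separate them; they differ in that a five-membered aromatic ring with 2 hetero atoms replaces a six-membered non-aromatic ring with 1 hetero atom, and in that the defined stereocentre of the leaving group is gone. Nothing measured here explains why the number moves.

A single exchange cannot show which of these differences matters, and a 1H-indol-2-yl group, with carbon in place of one ring nitrogen, or a plain phenyl group at the same place would help to separate them. On these data alone, it also remains open whether the same exchange would give a similar step in a compound carrying the isopropyl group of compound 2.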